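A few compounds are considered here, and "the series" means these few. Any claim that something is new, unique, unknown or untested is made for them only; others in the source may bear on it.

Measured so far in a functional assay on MIA PaCa-2 cells (Homo sapiens) for antiproliferative activity, read by MTT assay, with a stated time of 72 h; on this read-out lower numbers stand for an effect already at smaller amounts and higher numbers for an effect only at larger amounts of compound:
compound 1, `CNC(=O)c1cccc(Cn2nc(C)c(NC(=O)c3ccc(COc4ccccc4)cc3)c2C)c1`, gives 6200 nM
compound 2, `CNC(=O)c1cccc(Cn2nc(C)c(NC(=O)c3ccc(COc4ccc(C)cc4)cc3)c2C)c1`, gives 2600 nM
compound 3, `CNC(=O)c1cccc(Cn2nc(C)c(NC(=O)c3ccc(COc4ccc(C(F)(F)F)cc4)cc3)c2C)c1`, gives 800 nM

All three share the core of compound 1 and differ only on the phenoxy ring. From compound 1 to compound 2 the change is methyl in place of hydrogen on an aromatic carbon, and the step is a 2.4-fold lower number from compound 1 to compound 2 (0.38 log units; beyond the scatter). From compound 1 to compound 3 the change is trifluoromethyl in place of hydrogen on an aromatic carbon, with a 7.8-fold lower number from compound 1 to compound 3 (0.89 log units; beyond the scatter). Between the two substituted analogues the step is a 3.3-fold lower number from compound 2 to compound 3 (0.51 log units; beyond the scatter). Compound 3 therefore carries the lowest number of the three, and both of its steps to the others lie beyond the scatter.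

Compound 4, `CNC(=O)c1cccc(Cn2nc(C)c(NC(=O)c3ccc(COc4ccc(C(F)(F)F)cc4C)cc3)c2C)c1`, has not yet been measured in this assay. It differs from compound 3 by methyl in place of hydrogen on an aromatic carbon. Within the data shown here, this is the same kind of change as the one from compound 1 to compound 2, but not the same: there the methyl entered para to a large group, here it enters ortho to a large group and meta to a trifluoromethyl group. Among the measured compounds shown here, only the one methyl step is available, and no pair here shows what a methyl at this second place does. The step from compound 3 to compound 4 in this assay is expected to be a 1.5-fold lower number from compound 3 to compound 4 (0.16 log units; within the scatter), a smaller lowering than a 2.4-fold lower number from compound 1 to compound 2 (0.38 log units; beyond the scatter), because the measured precedent is a 2.4-fold lower number from compound 1 to compound 2 (0.38 log units; beyond the scatter) and the change is only of the same kind. Compound 4 is accordingly estimated at 550 nM in this assay, with a range from 250 nM to 1300 nM.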

Compound 4, half-maximal effective concentration in the MIA PaCa-2 assay: 620 nM
Estimate against measurement, compound 4: 1.1-fold (0.05 log units) below; the measured number falls inside the stated range.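

In the MIA PaCa-2 assay the methyl change on compound 3 gives a 1.3-fold lower number from compound 3 to compound 4 (0.11 log units; within the scatter) and, set beside the earlier methyl step, it shows no difference that stands out from the scatter: the same change on two cores in the MIA PaCa-2 assay, a 2.4-fold lower number (0.38 log units; beyond the scatter) from compound 1 to compound 2 and a 1.3-fold lower number (0.11 log units; within the scatter) from compound 3 to compound 4, 1.8-fold (0.27 log units) apart, within the scatter of two such steps. Among these compounds, this agreement does not show that the methyl step carries over unchanged, since the smaller step on its own cannot be told from no change, and the methyl on compound 4 sits ortho to a large group and meta to a trifluoromethyl group, so place and core vary together across only two pairs. Against the less substituted analogues, the MIA PaCa-2 assay gives a 4.2-fold lower number from compound 2 to compound 4 (0.62 log units; beyond the scatter) and also a 10-fold lower number from compound 1 to compound 4 (1.00 log units; beyond the scatter), so the 2-methyl-4-(trifluoromethyl)phenyl group keeps the lowering reached with compound 3, while the added methyl goes with a higher measured solubility: the measured solubility of compound 3, 67300 nM, and of compound 4, 166000 nM, a 2.5-fold higher number (0.39 log units; beyond the scatter). In a physicochemical assay for solubility, measured as thermodynamic solubility, with a stated time of 48 h, at pH 7.4 (a higher number here means a more soluble compound, a lower number a less soluble compound), compound 3 gives 67300 nM and compound 4 gives 166000 nM.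

The compounds shown leave open what a methyl at this same place does on the unsubstituted phenoxy ring of compound 1, a pair that would separate place from core. Also open, going by these compounds, is how a chlorine, a methoxy group or an amine on the phenoxy ring would behave in either read-out, and whether the solubility step recurs on another core.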